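This account rests on a few compounds, and the source may have more. Where it says the series, first, only, none or still open, it means among the compounds named here.

Compound 1 `COc1ccc(-c2ccc3c(c2)C(=O)C(=O)N3Cc2ccc(C)cc2)cc1`: 330 nM
Compound 2 `COc1ccc(CN2C(=O)C(=O)c3cc(-c4ccc(F)cc4)ccc32)cc1`: 3150 nM

For the measured compounds named here, in a functional assay on HepG2 cells (Homo sapiens) for antiproliferative activity, read by MTT assay, with a stated time of 48 h (on this read-out higher numbers stand for weaker inhibition and lower numbers for stronger inhibition), compound 2 stands at the highest of the two numbers, and its only neighbour, compound 1, lies beyond the usual scatter below it. Compound 3 `COc1ccc(CN2C(=O)C(=O)c3cc(-c4ccncc4)ccc32)cc1` is not yet measured; it differs from compound 2 in one place: pyridin-4-yl in place of 4-fluorophenyl on an aromatic carbon. No measured pair among these compounds shows a change of this kind, so there is nothing to size the step from. The step of a 1.3-fold lower number from compound 2 to compound 3 (0.10 log units; within the scatter) is expected to stay within the scatter, with no clear direction. Compound 3 is estimated at 2500 nM, between 800 nM and 8000 nM.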

Compound 3, half-maximal inhibitory concentration: > 10000 nM
Compound 3 was reported as a limit; the forecaster's own chance of this, stated with the estimate: 10%; middle value at least 4.0-fold (0.60 log units) from the limit.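

In this assay, this position on the shared core proves sensitive to which ring it carries: pyridin-4-yl in place of 4-fluorophenyl brings an at least 3.1-fold higher number from compound 2 to compound 3 (0.50 log units; beyond the scatter). Exchanging one six-membered aromatic ring for another is therefore not a neutral swap here, even though the two differ by only a few atoms. Compound 3 is reported only as a limit of the assay, not as a number: the limit of > 10000 nM in this assay, at which 1 of the 3 values shown sits.

The true size of the step remains open, and so does its cause. Also open, on these data alone, is how a plain phenyl, an amine or a carboxylic acid would fare at this position.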